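The source may report more compounds than this note shows. Statements on the series, on what has been measured and on what is new or still open speak of the compounds shown alone.

Measured compounds:
Compound 1, `CCCC[S+]([O-])c1sc2nc(-c3nccs3)cc(-c3ccc(C(=O)N(C)C)cc3)c2c1N`, gives 5.9 nM in an assay for inhibition of 15-hydroxyprostaglandin dehydrogenase [NAD(+)] (Homo sapiens), read by fluorescence, with a stated time of 15 min, in the presence of a further agent that is not named here; a lower number here means a stronger inhibitor, a higher number a weaker inhibitor.
Compound 2, `CCC[S+]([O-])c1sc2nc(-c3cccs3)cc(C(=O)N(C)C)c2c1N`, gives 14.7 nM in this assay.

Going by the values given here, compound 1 holds the lower number of the two; compound 2 sits at a number higher by an amount beyond the usual scatter, but these two differ in more than one place, so no single-change step can be drawn from them. Compound 3, `CCCC[S+]([O-])c1sc2nc(-c3nccs3)cc(-c3ccc(CNC(=O)NCC)cc3)c2c1N`, differs from compound 1 in one place only: ((ethylcarbamoyl)amino)methyl in place of dimethylcarbamoyl on an aromatic carbon. Among the compounds with values here, no measured pair isolates a change of this kind, so the direction in this assay is open. The expectation is a small step, not clearly beyond the scatter, with a slight lean towards a higher number. The measured compounds give no basis for predicting a gain from the change. Compound 3 is estimated at 9 nM, with a range from 3 nM to 30 nM. The implied step a 1.5-fold higher number from compound 1 to compound 3 (0.18 log units; within the scatter) is expected to stay near the scatter.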

Compound 3, half-maximal inhibitory concentration: 2.1 nM
Compound 3: middle estimate off by 4.3-fold (0.63 log units), on the high side; the measured number lies below the stated range.
By their numbers in this assay, from the lowest: compound 3; then compound 1; then compound 2.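

Going by these compounds alone, the aromatic carbon para to a large group accepts ((ethylcarbamoyl)amino)methyl in place of dimethylcarbamoyl in this assay, with a 2.8-fold lower number from compound 1 to compound 3 (0.45 log units; beyond the scatter) as the only single-place step so far. Compound 1 and compound 2 could not isolate any one position, whereas this pair shows that the number at this position responds to the group placed there. The entering group is larger, with 7 heavy atoms against 5, and has 2 hydrogen-bond donors against 0, yet no measured evidence explains the lower number.

The compounds shown do not separate the contributions of the methylene link, the carbonyl unit and the ethyl end of the entering group. Going by these compounds, it remains open how this position would respond to a simple aminomethyl group, a carboxylic acid, or a butyl chain in place of the ethyl end.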